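The source may hold more compounds than are shown below. What is called first, only, known or untested is meant among the compounds shown, and "the series" means these compounds.

Measured compounds:
- compound 1, `CCCCNc1nc(N)nc2c1CN(C)CC2`: in an assay on HEK293 cells for agonist activity at Toll-like receptor 8 (Homo sapiens), read by a luciferase reporter, with a stated time of 6 h (on this read-out higher numbers stand for an effect only at larger amounts of compound and lower numbers for an effect already at smaller amounts), compound 1 gives 0.03 uM
- compound 2, `CCCCNc1nc(N)nc2c1CN(C(=O)C1CCC1)CC2`: compound 2 gives 0.4 uM
- compound 3, `CCCCNc1nc(N)nc2c1CN(C(=O)c1ccccn1)CC2`: compound 3 gives 2.9 uM

Compound 3 stands highest of the three numbers in this assay; its nearest neighbour is compound 2, with a 7.3-fold higher number from compound 2 to compound 3 (0.86 log units; beyond the scatter) separating them, and compound 1 lies furthest away, with a 97-fold higher number from compound 1 to compound 3 (1.99 log units; beyond the scatter).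

Compound 4, `CCCCNc1nc(N)nc2c1CN(C(=O)c1cscn1)CC2`, is not yet measured. It differs from compound 3 in one place: 1,3-thiazol-4-yl in place of pyridin-2-yl on a carbonyl carbon

Within the data shown here, two steps bear on this change. The step of a 97-fold higher number from compound 1 to compound 3 (1.99 log units; beyond the scatter) and the step of a 7.3-fold higher number from compound 2 to compound 3 (0.86 log units; beyond the scatter) both concern what sits on the carbonyl carbon, and both moved the number upward when an aromatic ring entered. Among the measured compounds shown here, for compound 4 the carbonyl carbon again carries an aromatic ring, so no shift of that kind is expected; the two groups exchanged are of like size, and no measured pair shows the effect of moving from one aromatic ring to another. The step of a 1.2-fold lower number from compound 3 to compound 4 (0.06 log units; within the scatter) is therefore expected to stay within the scatter. Compound 4 is estimated at 2.5 uM, with a range from 0.8 uM to 8 uM.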

Compound 4, minimum effective concentration: 0.5 uM
The estimate for compound 4 lay 5.0-fold (0.70 log units) above the measured number, and the stated range ends above it.
By their numbers in this assay, from the lowest: compound 1; then compounds 2 and 4 (each within the scatter of the next); then compound 3.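

Exchanging one aromatic ring for another on the carbonyl carbon is not a silent change: in this assay there is a 5.8-fold lower number from compound 3 to compound 4 (0.76 log units; beyond the scatter), so the high number of compound 3 belongs to pyridin-2-yl and not to aromatic rings as a class. With a 1.3-fold higher number from compound 2 to compound 4 (0.10 log units; within the scatter), 1,3-thiazol-4-yl and cyclobutyl cannot be told apart here, while a 17-fold higher number from compound 1 to compound 4 (1.22 log units; beyond the scatter) shows that this carbonyl group still stands well short of methyl on the amine nitrogen in a ring. No measurement at hand accounts for the difference between the two rings.

Going by these compounds, whether phenyl or furan-2-yl on the carbonyl carbon would follow pyridin-2-yl or 1,3-thiazol-4-yl stays open. So does whether ethyl or benzyl on the amine nitrogen in a ring would stay close to methyl.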